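Arylidene series, two chlorophenyl groups, cytotoxicity notes

A few compounds are considered here, and "the series" means these few. Any claim that something is new, unique, unknown or untested is made for them only; others in the source may bear on it.

Of the compounds shown here, two have numbers so far. Compound 1 `COc1cc(C=C2C(=O)N(c3ccc(Cl)cc3)N(c3ccc(Cl)cc3)C2=O)cc(OC)c1OC` gives 17300 nM in a functional assay on MGC-803 cells (Homo sapiens) for cytotoxicity, read by MTT assay, with a stated time of 72 h; a higher number here means a weaker inhibitor, a lower number a stronger inhibitor. Compound 2 `COc1cc(C=C2C(=O)N(c3ccc(Cl)cc3)N(c3ccc(Cl)cc3)C2=O)ccc1O` gives 21800 nM in this assay, the highest of the two numbers; its nearest neighbour is compound 1, whose number is within the scatter of that of compound 2, so the two compounds cannot be told apart on these data.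

Compound 3 `O=C1C(=Cc2ccco2)C(=O)N(c2ccc(Cl)cc2)N1c1ccc(Cl)cc1` has not yet been measured in this assay. Its structural difference from compound 2 is furan-2-yl in place of 4-hydroxy-3-methoxyphenyl on a double-bonded chain carbon bound to a double-bonded ring carbon. For the measured compounds named here, no measured pair shows a step of this kind, so there is nothing in the numbers to say how it will act; the only guide is that compound 1 and compound 2, which share the rest of the structure, both sit in the same weak range.

The step expected from compound 2 to compound 3 is small, within the scatter or slightly towards a higher number, a 1.1-fold higher number from compound 2 to compound 3 (0.06 log units; within the scatter). Compound 3 is therefore estimated at 25000 nM in this assay, with a plausible range from 8000 nM to 80000 nM.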

Compound 3, half-maximal inhibitory concentration: 12800 nM
Beside the measured number, compound 3's estimate is 2.0-fold (0.29 log units) above it, within the range that was stated.
By their numbers in this assay, from the lowest: compounds 3, 1 and 2 (each within the scatter of the next).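

At the place on a double-bonded chain carbon bound to a double-bonded ring carbon, furan-2-yl in place of 4-hydroxy-3-methoxyphenyl gives a 1.7-fold lower number from compound 2 to compound 3 (0.23 log units; within the scatter) in this assay, the first step readable at this position, and it does not separate the two compounds. The change takes out a six-membered aromatic ring of carbon only, with its hydrogen-bond donor, and puts in a five-membered aromatic ring with 1 hetero atom and 0 hydrogen-bond donors, yet the result in this assay stays within the scatter, so this position tolerates that exchange without a readable shift on these numbers. Nothing available bears on the cause of this result.

As far as these compounds go, all three compounds carry an aromatic ring at this position, so it remains open whether an amine, a carboxylic acid or a longer alkyl chain there would move the number in this assay beyond the scatter. From the compounds shown here alone, the two chlorophenyl groups are common to all three compounds, and what replacing them with plain phenyl would do also remains open.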